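A few compounds are considered here, and "the series" means these few. Any claim that something is new, unique, unknown or untested is made for them only; others in the source may bear on it.

Measured so far in a functional assay on 786-0 cells (Homo sapiens) for inhibition, read by sulforhodamine B assay, with a stated time of 48 h; a higher number here means a weaker inhibitor of growth, a lower number a stronger inhibitor of growth:
Compound 1 `CC1=CC[C@H](C(C)(C)NC(=S)N/N=C/c2ccccc2Cl)CC1` gives 85500 nM in this assay.
Compound 2 `CC1=CC[C@H](C(C)(C)NC(=S)N/N=C/c2ccco2)CC1` gives 11700 nM in this assay.

Among the compounds with values here, compound 2 holds the lower of the two numbers; its only neighbour is compound 1, and the step from compound 1 to compound 2 is a 7.3-fold lower number from compound 1 to compound 2 (0.86 log units; beyond the scatter), a modest gain from exchanging the ring on the carbon with a double bond to nitrogen. Compound 3 `CC1=CC[C@H](C(C)(C)NC(=S)N/N=C/c2ccc[nH]2)CC1` has not yet been measured. It differs from compound 2 in one place: 1H-pyrrol-2-yl in place of furan-2-yl on a carbon with a double bond to nitrogen. Within the data shown here, no measured step exchanges furan-2-yl for 1H-pyrrol-2-yl. Among the measured compounds shown here, the one step available shows that this position responds to a change of ring, but the two rings in question are both five-membered with one hetero atom, so the data give no direction for the present swap. The step from compound 2 to compound 3 is therefore expected to be small, a 1.2-fold lower number from compound 2 to compound 3 (0.07 log units; within the scatter), likely within the scatter. For compound 3 a value of 10000 nM is estimated, with a range from 3500 nM to 30000 nM.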

Compound 3, concentration for 50% growth inhibition: 20800 nM
The estimate for compound 3 lay 2.1-fold (0.32 log units) below the measured number, and the stated range covers the measured number.
By their numbers in this assay, from the lowest: compounds 2 and 3 (each within the scatter of the next); then compound 1.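

In this assay the exchange of furan-2-yl for 1H-pyrrol-2-yl on a carbon with a double bond to nitrogen gives a 1.8-fold higher number from compound 2 to compound 3 (0.25 log units; within the scatter) and so does not separate the two five-membered aromatic rings, even though the entering group has 1 hydrogen-bond donor and 0 hydrogen-bond acceptors, while the leaving group has 0 hydrogen-bond donors and 1 hydrogen-bond acceptor. The exchange of 2-chlorophenyl for 1H-pyrrol-2-yl gives a 4.1-fold lower number from compound 1 to compound 3 (0.61 log units; beyond the scatter) and, taken with a 7.3-fold lower number from compound 1 to compound 2 (0.86 log units; beyond the scatter) for furan-2-yl, shows that among these three compounds both five-membered rings with 1 hetero atom give lower numbers than 2-chlorophenyl, with no compound here going against this. No supporting evidence is available to explain any of these steps.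

The compounds shown leave open whether the higher number of compound 1 belongs to the phenyl ring itself or to its chlorine, which an unsubstituted phenyl group at this position would separate. They also leave open how this position would respond to a ring carrying an amine or a carboxylic acid, or to a pyridin-2-yl group.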